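Azole replacement at the aromatic carbon: compound 4

This account rests on a few compounds, and the source may have more. Where it says the series, first, only, none or still open, it means among the compounds named here.

Measured in an in vitro functional assay on cells (Fibroblast) for agonist activity at Alpha-1D adrenergic receptor (Homo sapiens); a lower number here means that less compound is needed, a higher number that more compound is needed for the effect:
compound 1 `Cn1ncnc1-c1ccccc1NCC1=NCCN1` gives 63.1 nM
compound 2 `c1ccc(-c2cn[nH]c2)c(NCC2=NCCN2)c1` gives 20 nM
compound 3 `CCn1cc(-c2ccccc2NCC2=NCCN2)cn1` gives only a limit of the assay, < 100000 nM

Compound 2 holds the lowest of the two readable numbers; the nearest is compound 1, reached by a 3.2-fold lower number from compound 1 to compound 2 (0.50 log units; beyond the scatter). Compound 3 sits at a limit (the limit of < 100000 nM in this assay, at which 1 of the 3 values shown sits), so a step that the limit leaves unreadable from compound 2 to compound 3 cannot be read. Compound 4 `Cn1ccnc1-c1ccccc1NCC1=NCCN1` alters compound 2 by 1-methyl-1H-imidazol-2-yl in place of 1H-pyrazol-4-yl on an aromatic carbon. Going by the values given here, the one readable step, from compound 1 to compound 2, exchanged 1-methyl-1H-1,2,4-triazol-5-yl for 1H-pyrazol-4-yl; compound 4 runs back toward a methylated azole with 0 hydrogen-bond donors. A modest rise in this assay, of roughly that size, is therefore expected: a 3.0-fold higher number from compound 2 to compound 4 (0.48 log units; beyond the scatter). Compound 4 is estimated at 60 nM, range 15 nM to 250 nM.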

Compound 4, half-maximal effective concentration: 200 nM
Compound 4: the middle estimate sits 3.3-fold (0.52 log units) below what was measured; low and high end bracket the measured number.
By their numbers in this assay, from the lowest: compound 2; then compound 1; then compound 4.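

Exchanging 1H-pyrazol-4-yl, with 1 hydrogen-bond donor, for 1-methyl-1H-imidazol-2-yl, with 0, gives a 10-fold higher number from compound 2 to compound 4 (1.00 log units; beyond the scatter) in this assay. The two methylated azoles also separate, with a 3.2-fold higher number from compound 1 to compound 4 (0.50 log units; beyond the scatter), so at this aromatic carbon the choice of azole matters even when both groups carry a methyl. No measured property of these groups bears on either step.

Going by these compounds, it remains open whether the methyl or the imidazole ring accounts for the step from the pyrazole. A 1H-imidazol-2-yl group would separate the two, and an aminomethyl group would test whether an azole is needed here at all.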